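A few compounds are considered here, and "the series" means these few. Any claim that something is new, unique, unknown or untested is made for them only; others in the source may bear on it.

Measured so far in a functional assay on MV4-11 cells (Homo sapiens) for cytotoxicity, read by colorimetric assay and MTT assay, with a stated time of 3 days, tested at 20 uM; a lower number here means a stronger effect, a higher number a weaker effect of the compound at the concentration tested:
compound 1, `COc1ccc(-n2cc(-c3ccccc3)c(-c3ccc4c(c3)NC(=O)CO4)n2)cc1`: 59.9%
compound 2, `O=C1COc2ccc(-c3nn(-c4ccc(Cl)cc4)cc3-c3ccccc3)cc2N1`: 91.9%

Among the measured compounds shown here, compound 2 holds the higher of the two numbers, that is the weaker effect; the only measured step, a number 32 percentage points higher from compound 1 to compound 2 (beyond the scatter), separates it from compound 1 and lies beyond the scatter.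

Compound 3 is `O=C1COc2ccc(-c3nn(-c4cc(Cl)cc(Cl)c4)cc3-c3ccccc3)cc2N1` and remains to be measured in this assay. It differs from compound 2 in one place: 3,5-dichlorophenyl in place of 4-chlorophenyl on an aromatic nitrogen.

The step of a number 32 percentage points higher from compound 1 to compound 2 (beyond the scatter) is the only one that touches the same phenyl on the aromatic nitrogen, and it was large. It concerns, however, the exchange of one group for another at a single carbon of that phenyl, and says nothing direct about a second chlorine arranged as in 3,5-dichlorophenyl. The footing for an expectation is therefore thin. Taken at face value, chlorine on this phenyl is associated with the weaker effect in compound 2, and a second chlorine is not expected to reverse that. Compound 3 is expected to stay close to compound 2, with a step of a number 3.9 percentage points lower from compound 2 to compound 3 (within the scatter) within the scatter. The estimate for compound 3 in this assay is 88%, in the range 68% to 100%.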

Compound 3, a percentage reported as activity, at one concentration (the size of the read-out at that concentration, not a potency): 50.5%
Estimate against measurement, compound 3: 37.5 percentage points above; measured number below the stated range.
By their numbers in this assay, from the lowest: compounds 3 and 1 (each within the scatter of the next); then compound 2.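

In this assay the step of a number 41.4 percentage points lower from compound 2 to compound 3 (beyond the scatter) shows that this position on the aromatic nitrogen responds strongly to the substitution pattern of the phenyl, so the weak effect of compound 2 does not carry over to every chlorine-bearing phenyl here. The step of a number 9.4 percentage points lower from compound 1 to compound 3 (within the scatter) puts 3,5-dichlorophenyl and 4-methoxyphenyl level at this position, and 4-chlorophenyl alone stands apart among the three compounds, with compound 2 beyond the scatter of both others. No measurement at hand accounts for this difference between the groups.

The change from 4-chlorophenyl to 3,5-dichlorophenyl alters both the number of chlorines and where they sit, and the compounds shown do not separate these two contributions. Going by these compounds, how an amine, a carboxylic acid or a longer chain such as an ethoxy group on this phenyl would read out remains open, as does whether the same ranking of groups would hold on a core with a different group in place of the phenyl on the five-membered ring.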